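Capping group changes on the shared core

The compounds below may be only part of what the source reports. "The series", "measured", "known", "first", "only" and "open" are said of these compounds alone.

Measured so far in an assay on isolated protein for inhibition of histamine H2 receptor (Cavia porcellus); on this read-out higher numbers stand for weaker binding and lower numbers for tighter binding:
compound 1 `O=C(NCCCOc1cccc(CN2CCCCC2)c1)Nc1cccc(C(F)(F)F)c1` — 813 nM
compound 2 `O=C(NCCCOc1cccc(CN2CCCCC2)c1)NCc1ccccc1` — 347 nM
compound 3 `CC(C)(C)NC(=O)NCCCOc1cccc(CN2CCCCC2)c1` — 2090 nM

Compound 1 stands second highest of the three numbers, with a 2.3-fold lower number from compound 1 to compound 2 (0.37 log units; beyond the scatter) on one side and a 2.6-fold higher number from compound 1 to compound 3 (0.41 log units; beyond the scatter) on the other; both steps lie beyond the scatter.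

The unmeasured compound 4 `CCC(C)NC(=O)NCCCOc1cccc(CN2CCCCC2)c1` differs from compound 1 in one place: sec-butyl in place of 3-(trifluoromethyl)phenyl on an amide-type nitrogen.

The step that bears most directly on this change is a 2.6-fold higher number from compound 1 to compound 3 (0.41 log units; beyond the scatter), where tert-butyl took the place of the same 3-(trifluoromethyl)phenyl; a 6.0-fold higher number from compound 2 to compound 3 (0.78 log units; beyond the scatter) points the same way, benzyl to tert-butyl. A rise of similar size is therefore expected in this assay, a 2.1-fold higher number from compound 1 to compound 4 (0.32 log units; beyond the scatter).

Compound 4 is estimated at 1700 nM, with a range of 700 nM to 4000 nM.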

Compound 4, dissociation constant: 95.5 nM
Compound 4: the middle estimate sits 18-fold (1.25 log units) above what was measured; measured number outside the range, below it.
By their numbers in this assay, from the lowest: compound 4; then compound 2; then compound 1; then compound 3.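

In this assay, the cap on this amide-type nitrogen does not sort into aromatic against aliphatic: sec-butyl lies below both aromatic-bearing caps (an 8.5-fold lower number from compound 1 to compound 4 (0.93 log units; beyond the scatter) and a 3.6-fold lower number from compound 2 to compound 4 (0.56 log units; beyond the scatter)), whereas tert-butyl lay above them. The largest step (a 22-fold lower number from compound 3 to compound 4 (1.34 log units; beyond the scatter)) separates two butyl isomers, so one cannot stand in for the other at this position. No measurement available here accounts for these steps.

On these data alone, whether an n-butyl chain, isopropyl or cyclopentyl on the same nitrogen tracks sec-butyl or tert-butyl remains open. So does any difference between the two separate enantiomers of sec-butyl.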